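The compounds below may be only part of what the source reports. "The series", "measured", "known", "first", "only" and "open" are said of these compounds alone.

Measured in a functional assay on A-375 cells (Homo sapiens) for antiproliferative activity, read by CCK-8 assay, with a stated time of 72 h, tested at 2 uM; a higher number here means a stronger effect of the compound at the concentration tested, a lower number a weaker effect:
- compound 1 `Nc1ccccc1NC(=O)c1ccc(CSC(=S)N2CCN(C3CCCCC3)CC2)cc1` gives 31.7%
- compound 2 `Nc1ccccc1NC(=O)c1ccc(CSC(=S)N2CCc3ccc([N+](=O)[O-])cc32)cc1` gives 22.1%
- compound 3 `N#Cc1ccc(N2CCN(C(=S)SCc3ccc(C(=O)Nc4ccccc4N)cc3)CC2)cc1` gives 41.4%

Compound 2 has the lowest of the three numbers in this assay. Its nearest neighbour is compound 1, and the two values sit within the scatter of each other, so no order between them is claimed. Compound 3 stands beyond the scatter above compound 2. Going by the values given here, the one measured step, a number 9.7 percentage points higher from compound 1 to compound 3 (within the scatter), concerns the amine nitrogen in a ring and is within the scatter.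

Compound 4 `Nc1ccccc1NC(=O)c1ccc(CSC(=S)N2CCc3ccccc32)cc1` is not yet measured in this assay. It differs from compound 2 by hydrogen in place of nitro on an aromatic carbon. Among the compounds with values here, no measured step touches this position or this group; the step from compound 1 to compound 3 changes a different part of the molecule and is therefore not a guide to size or direction here. With nothing comparable to go on, no shift beyond the scatter is expected, and the estimate is kept close to compound 2 with a wide range. Compound 4 is expected to give 25% in this assay, within 10% to 42%. The expected step is a number 2.9 percentage points higher from compound 2 to compound 4 (within the scatter).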

Compound 4, a percentage reported as inhibition, at one concentration (the size of the read-out at that concentration, not a potency): 25.7%
Compound 4: the middle estimate sits 0.7 percentage points below what was measured; the range from low to high includes it.
By their numbers in this assay, from the lowest: compounds 2, 4, 1 and 3 (each within the scatter of the next, the first and the last beyond it).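

In this assay, going by these compounds alone, hydrogen in place of nitro gives a number 3.6 percentage points higher from compound 2 to compound 4 (within the scatter) and is the first measured change on this aromatic carbon of the fused system. The nitro group is therefore not required for the level of inhibition seen in compound 2 at the one concentration tested, and the exchange of three heavy atoms for a hydrogen atom leaves the read-out inside the usual scatter. No measurement available here bears on why this exchange has so little effect.

Still open, on these data alone, is whether an amine, a methoxy group or a chlorine atom on the same aromatic carbon would also stay within the scatter. Equally open is whether a group on another carbon of this ring would behave as the nitro group does here, since the compounds shown vary only this one carbon of that ring.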